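The source may hold more compounds than are shown below. What is called first, only, known or untested is meant among the compounds shown, and "the series" means these compounds.

In an assay on isolated protein for inhibition of poly(A)-specific ribonuclease PARN (Homo sapiens) (a lower number here means a stronger inhibitor, a higher number a weaker inhibitor), compound 1 `O=c1[nH]c2ncn(Cc3ccncc3)c2c(=O)n1O` gives 245000 nM. Compound 2 `O=c1[nH]c2ncn(C3CCCCC3)c2c(=O)n1O` belongs to the same study, but in this assay compound 2 gives "not determined" (no result reported). Compound 3 `CCCCOCCCn1cnc2[nH]c(=O)n(O)c(=O)c21` likewise gives "not determined" (no result reported) in this assay. Within the data shown here, compound 1 is therefore the only member of this small set with a number attached to it; no step between two measured compounds can be drawn, and compound 1 stands alone as the single point of reference. Compound 4 `O=c1[nH]c2ncn(Cc3ccccn3)c2c(=O)n1O` keeps every atom of compound 1 and differs only in how they are joined: pyridin-2-yl in place of pyridin-4-yl on a saturated chain carbon bound to an aromatic nitrogen. Among the measured compounds shown here, there is no measured pair to show what this rearrangement does in this assay, so nothing sets the size of the step. The step of a 1.1-fold lower number from compound 1 to compound 4 (0.05 log units; within the scatter) is expected to stay within the usual scatter, with no direction favoured. On that basis compound 4 is expected to come out near 220000 nM in this assay, within a range from 70000 nM to 700000 nM.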

Compound 4, half-maximal inhibitory concentration: 119000 nM
Estimate against measurement, compound 4: 1.8-fold (0.27 log units) above; the range from low to high includes it.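

In this assay, the place on a saturated chain carbon bound to an aromatic nitrogen now proves sensitive to how the same atoms are joined: pyridin-2-yl in place of pyridin-4-yl gives a 2.1-fold lower number from compound 1 to compound 4 (0.31 log units; beyond the scatter). The two groups have the same heavy atoms and the same counts of hydrogen-bond donors and acceptors, so this difference in the numbers arises without any change in those counts, and compound 4 is the stronger inhibitor of this pair. Nothing available here accounts for the difference between the two pyridine attachments.

The compounds shown leave open whether pyridin-3-yl, a phenyl ring or an amine at this place would give a lower number than compound 4 gives. They also leave open how a longer chain between the shared core and the pyridine ring would read in this assay.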